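The source may report more compounds than this note shows. Statements on the series, on what has been measured and on what is new or still open speak of the compounds shown alone.

Measured compounds:
compound 1, `c1ccc(OCCCCCOc2cccc(-c3cc4cc(C5=NCCN5)ccc4o3)c2)cc1`, 2600 nM in an ADME assay on L6 cells (Rattus norvegicus) for cytotoxicity, read by resazurin assay, with a stated time of 70 h; a higher number here means a weaker inhibitor, a lower number a stronger inhibitor
compound 2, `c1ccc(OCCCCCCOc2cccc(-c3cc4cc(C5=NCCN5)ccc4o3)c2)cc1`, 2500 nM
compound 3, `N=C(N)c1ccc2cc(-c3cccc(OCCCCCOc4ccccc4)c3)oc2c1`, 4100 nM

Compounds 1 and 2 share a core and differ in one place. The change from compound 1 to compound 2 is phenoxymethyl in place of phenoxy on a saturated chain carbon, five bonds along the chain from an oxygen on an aromatic ring and in this assay it gives a 1.0-fold lower number from compound 1 to compound 2 (0.02 log units; within the scatter), so the two compounds sit within the usual scatter of each other and no direction can be read from them.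

Compound 3 carries a different core. In this assay compound 3 gives 4100 nM, the highest of the three numbers, though it stands within the scatter of both compound 1 and compound 2. The difference between the core of compound 3 and the core of compound 1 is not broken down here.

Compound 4, `N=C(N)c1ccc2cc(-c3cccc(OCCCCCCOc4ccccc4)c3)oc2c1`, has not yet been measured in this assay. It is related to compound 3 by phenoxymethyl in place of phenoxy on a saturated chain carbon, five bonds along the chain from an oxygen on an aromatic ring, which is the same change that turns compound 1 into compound 2, made at the same place along the chain. Since that change gave a 1.0-fold lower number from compound 1 to compound 2 (0.02 log units; within the scatter), the step from compound 3 to compound 4 is expected to be small, about a 1.0-fold lower number from compound 3 to compound 4 (0.01 log units; within the scatter). On that basis compound 4 is expected to give roughly 4000 nM in this assay, with a likely range from 2000 nM to 8000 nM.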

Compound 4, half-maximal inhibitory concentration: 4300 nM
Compound 4: middle estimate off by 1.1-fold (0.03 log units), on the low side; measured number inside the range.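

In this assay, replacing phenoxy with phenoxymethyl on the core of compound 3 gives a 1.0-fold higher number from compound 3 to compound 4 (0.02 log units; within the scatter), so on this second core, as on the first, the step cannot be told apart from repeated measurement. Set beside the earlier step, the same change reads alike on the two cores: the same change on two cores in this assay, a 1.0-fold lower number (0.02 log units; within the scatter) from compound 1 to compound 2 and a 1.0-fold higher number (0.02 log units; within the scatter) from compound 3 to compound 4, 1.1-fold (0.04 log units) apart, within the scatter of two such steps. This shows that, on these two cores and in this assay, the change at this place on the chain carries across without a readable effect, but it does not show that the change would be as quiet on any other core or at any other place, and since both steps lie within the scatter, their agreement does not show that an effect of any size transfers.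

The compounds shown leave open whether a longer chain, such as one ending in 2-phenoxyethyl or 3-phenoxypropyl in place of phenoxymethyl, would still give a step within the scatter on both cores. They also leave open how an amine within the chain, or a chlorine or a methoxy group on the phenoxy ring, would read in this assay.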